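The source may hold more compounds than are shown below. What is called first, only, known or untested is meant among the compounds shown, and "the series" means these compounds.

Measured compounds:

compound 1, `COc1ccc(CCCc2ccc(OC)c(OC)c2)c(O)c1`, giving 97.9%

compound 2, `COc1ccc(CCCc2ccc(OC)c(OC)c2OC)c(O)c1`, giving 96.3%

compound 3, `COc1ccc(C(=O)CCc2ccc(OC)c(OC)c2)c(O)c1`, giving 91.8%

All three values come from an ADME assay on RAW264.7 cells (Mus musculus) for cytotoxicity, read by MTT assay, with a stated time of 24 h, tested at 1.25 ug/mL; a lower number here means a stronger effect, a higher number a weaker effect of the compound at the concentration tested. Compound 2 is compound 1 with one change, (methoxy in place of hydrogen on an aromatic carbon), and this change made a number 1.6 percentage points lower from compound 1 to compound 2 (within the scatter). Compound 3 differs from compound 1 in more than one place; the difference between the two cores is not broken down here. Compound 3 gives the lowest of the three numbers, but its gaps to compound 1 and to compound 2 are both within the scatter, so no order among the three can be read from them.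

Compound 4, `COc1ccc(C(=O)CCc2ccc(OC)c(OC)c2OC)c(O)c1`, has not yet been measured in this assay. It arises from compound 3 by methoxy in place of hydrogen on an aromatic carbon, the same change as from compound 1 to compound 2, made at a place described in the same words. Within the data shown here, on that basis compound 4 is expected to show a number 1.8 percentage points lower from compound 3 to compound 4 (within the scatter), a step close in size to the one seen in compound 2 because of a number 1.6 percentage points lower from compound 1 to compound 2 (within the scatter). The expected value for compound 4 is therefore 90%, estimated to lie between 82% and 98%.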

Compound 4, a percentage reported as activity, at one concentration (the size of the read-out at that concentration, not a potency): 101%
Estimate against measurement, compound 4: 11 percentage points below; measured number above the stated range.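

In this assay, methoxy in place of hydrogen on an aromatic carbon gave a number 9.2 percentage points higher from compound 3 to compound 4 (within the scatter). Set beside the earlier step, the two cores do not separate for this change: the same change on two cores in this assay, a number 1.6 percentage points lower (within the scatter) from compound 1 to compound 2 and a number 9.2 percentage points higher (within the scatter) from compound 3 to compound 4, 10.8 percentage points apart, within the scatter of two such steps. Neither core therefore shows a step that stands clear of the scatter, and the opposite signs of the two steps carry no meaning, but these two pairs, read at a single concentration, do not show that the change is without effect on other cores or at other concentrations, nor that its step is truly the same on both cores.

The compounds shown leave open how the read-out behaves with other groups at this aromatic carbon, such as a fluorine atom, an amine or a carboxylic acid. Also open, from the compounds shown here alone, is what a longer chain would do in place of the chain that joins the two aromatic rings, and what would follow from replacing the hydroxy group.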